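The source may report more compounds than this note shows. Statements on the series, on what has been measured and on what is new or still open speak of the compounds shown alone.

Measured compounds in the series:
compound 1 `c1cc2cc(c1)-c1cnn3ccc(nc13)NCCOCCO2` — 1300 nM
compound 2 `COc1cc(-c2cnn3cc(OC)c(C(C)(C)O)nc23)ccn1` — 2700 nM
compound 3 `COc1cn2ncc(-c3ccnc(OC4CC4)c3)c2nc1-c1cnn(C)c1` — 860 nM

All three numbers come from an assay on isolated protein for inhibition of activin receptor type-2A (Homo sapiens), read by 33P incorporation, with a stated time of 20 min, in the presence of a further agent that is not named here; on this read-out lower numbers stand for stronger inhibition and higher numbers for weaker inhibition. Compound 2 stands at the highest of the three: compound 1 gives a lower number, beyond the scatter, and compound 3 a lower one still, also beyond the scatter. Among the measured compounds shown here, compound 2 is therefore the weakest inhibitor among the compounds measured so far.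

The next compound, compound 4 `COc1cc(-c2cnn3cc(OC)c(N(C)C)nc23)ccn1`, keeps the core of compound 2 and differs from it in one place:
dimethylamino in place of 1-hydroxy-1-methylethyl on an aromatic carbon

For the measured compounds named here, no pair of measured compounds differs in this single place, so no measured step exists to set the size of this change against. Compounds 1 and 3 differ from compound 2 in several places at once and say nothing about this exchange on its own. The expectation therefore rests on the position of compound 2 alone: a step in this assay of modest size, toward a lower number or within the scatter. For compound 4 the estimated value is 2000 nM with a range of 600 nM to 6000 nM. This estimate means an expected step of a 1.4-fold lower number from compound 2 to compound 4 (0.13 log units; within the scatter).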

Compound 4, half-maximal inhibitory concentration: 3000 nM
Estimate against measurement, compound 4: 1.5-fold (0.18 log units) below; low and high end bracket the measured number.
By their numbers in this assay, from the lowest: compounds 3 and 1 (each within the scatter of the next); then compounds 2 and 4 (each within the scatter of the next).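

In this assay, dimethylamino in place of 1-hydroxy-1-methylethyl on this aromatic carbon gives a 1.1-fold higher number from compound 2 to compound 4 (0.05 log units; within the scatter), the first step measured at this position. The two groups therefore cannot be told apart here, even though the change removes the hydrogen-bond donor of the leaving group, swaps its oxygen for the nitrogen of the entering group and gives up one heavy atom. With the rest of compound 2 held constant, none of these differences, taken together, moves the number beyond the scatter, and nothing at hand accounts for this result.

Going by these compounds, both groups compared are uncharged and have no ring, so it remains open whether a carboxylic acid, a primary amine or a longer chain such as 2-methoxyethoxy on this carbon would give a step beyond the scatter. Among the compounds shown here, also open is whether the exchange of 1-hydroxy-1-methylethyl for dimethylamino would stay this small with different groups elsewhere on the shared core, since only this one pair differs in this single place.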